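Shortening the amide side chain of a melanocortin ligand

The compounds below may be only part of what the source reports. "The series", "measured", "known", "first", "only" and "open" are said of these compounds alone.

Measured so far:
compound 1, `CC(C)[C@H](N)c1cccc(F)c1N1CCN(C(=O)[C@@H]2CCO[C@@H]2c2ccc(Cl)cc2)CC1`, gives 2100 nM in an assay on HEK293 cells for displacement of a labelled ligand from Melanocortin receptor 4 (Homo sapiens); a lower number here means a stronger inhibitor, a higher number a weaker inhibitor
compound 2, `CC(C)C[C@H](NCCN(C)C)c1cc(C(F)(F)F)ccc1N1CCN(C(=O)[C@H]2CS(=O)(=O)C[C@@H]2c2ccc(Cl)cc2)CC1`, gives 170 nM
compound 3, `CNCCC(=O)N[C@@H](CC(C)C)c1cc(C(F)(F)F)ccc1N1CCN(C(=O)[C@H]2CS(=O)(=O)C[C@@H]2c2ccc(Cl)cc2)CC1`, gives 190 nM

Of the three numbers, compound 3 stands second highest. Its nearest neighbour is compound 2: the step of a 1.1-fold higher number from compound 2 to compound 3 (0.05 log units; within the scatter) lies within the scatter, so the two cannot be told apart. Compound 1 is the furthest away, with a number beyond the scatter higher than that of compound 3; it also differs from compound 3 in several places at once, so nothing can be read from it about any single change.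

Compound 4, `CNCC(=O)N[C@@H](CC(C)C)c1cc(C(F)(F)F)ccc1N1CCN(C(=O)[C@H]2CS(=O)(=O)C[C@@H]2c2ccc(Cl)cc2)CC1`, differs from compound 3 only in the side chain on the amide nitrogen: methylamino in place of (methylamino)methyl on a saturated chain carbon bound to a carbonyl carbon. Among the compounds with values here, the one measured step that touches this side chain is a 1.1-fold higher number from compound 2 to compound 3 (0.05 log units; within the scatter), in which an amide was put in place of a plain amine, and it did not move the number beyond the scatter. Within the data shown here, no measured pair shortens the chain itself, so the shortening has no precedent here. The expectation for compound 4 is therefore a step of a 1.2-fold higher number from compound 3 to compound 4 (0.06 log units; within the scatter), none beyond the scatter, with a slightly higher number allowed for the loss of one chain carbon. Compound 4 is estimated at 220 nM, within a range from 90 nM to 550 nM.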

Compound 4, inhibition constant: 180 nM
Beside the measured number, compound 4's estimate is 1.2-fold (0.09 log units) above it; low and high end bracket the measured number.
By their numbers in this assay, from the lowest: compounds 2, 4 and 3 (each within the scatter of the next); then compound 1.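

In this assay, within the data shown here, methylamino in place of (methylamino)methyl on a saturated chain carbon bound to a carbonyl carbon gives a 1.1-fold lower number from compound 3 to compound 4 (0.02 log units; within the scatter), so the first measured change in the length of this side chain leaves compounds that cannot be told apart. The comparison with the plain amine side chain reads the same way: ((methylamino)methyl)carbonyl in place of 2-(dimethylamino)ethyl on an amine nitrogen gives a 1.1-fold higher number from compound 2 to compound 4 (0.02 log units; within the scatter), which shows that, on this core, the shorter amide side chain also matches the amine-linked chain within the scatter. Nothing available explains why these side chains cannot be distinguished in this assay.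

On these data alone, compounds 2, 3 and 4 all carry a side chain ending in an amine, so it stays open whether that end group matters at all, or whether a carboxylic acid, a hydroxyl or a plain acetyl group on the same nitrogen would give a number in the same range. As far as these compounds go, it also stays open how far the length of the chain can vary, since a longer chain or a free primary amine on this same core could fall either inside or beyond the scatter of these three compounds.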